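A few compounds are considered here, and "the series" means these few. Any claim that something is new, unique, unknown or untested is made for them only; others in the source may bear on it.

Compound 3 `CN(C(=O)N1CC[C@H](n2cnc3cc(-c4ccc(Cl)cc4)sc3c2=O)C1)[C@H]1CCN(Cc2ccoc2)C1` is one of three compounds compared in an assay on isolated protein for binding affinity to melanin-concentrating hormone receptor 1 (Homo sapiens) (a higher number here means a weaker inhibitor, a lower number a stronger inhibitor), where compound 3 gives 4 nM. Compound 1 `CN(C(=O)N1CC[C@H](n2cnc3cc(-c4ccc(Cl)cc4)sc3c2=O)C1)[C@H]1CCN(CC2CC2)C1` gives 3 nM in this assay, and the step of a 1.3-fold higher number from compound 1 to compound 3 (0.12 log units; within the scatter) stays within the scatter. Compound 2 `CN(C(=O)N1CC[C@H](n2cnc3cc(-c4ccc(Cl)cc4)sc3c2=O)C1)[C@H]1CCN(CC2CCCCC2)C1` gives 50 nM, and the step of a 13-fold lower number from compound 2 to compound 3 (1.10 log units; beyond the scatter) is large. Compound 4 `CN(C(=O)N1CC[C@H](n2cnc3cc(-c4ccc(Cl)cc4)sc3c2=O)C1)[C@H]1CCN(CC2CCOC2)C1` differs from compound 3 in a single place: oxolan-3-yl in place of furan-3-yl on a saturated chain carbon bound to an amine nitrogen in a ring. All three measured steps alter this same position. The step of a 17-fold higher number from compound 1 to compound 2 (1.22 log units; beyond the scatter) shows that a cyclohexyl ring here is costly, while a 1.3-fold higher number from compound 1 to compound 3 (0.12 log units; within the scatter) shows that furan-3-yl and cyclopropyl give alike numbers, and a 13-fold lower number from compound 2 to compound 3 (1.10 log units; beyond the scatter) recovers what cyclohexyl lost. Oxolan-3-yl is a five-membered non-aromatic ring of the same heavy-atom count as furan-3-yl; no measured step exchanges an aromatic ring for its saturated counterpart, so the direction is uncertain. Compound 4 is expected to weaken modestly in this assay, by about a 2.5-fold higher number from compound 3 to compound 4 (0.40 log units; beyond the scatter). The estimated value for compound 4 is 10 nM, with a range from 3 nM to 40 nM.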

Compound 4, inhibition constant: 4 nM
Beside the measured number, compound 4's estimate is 2.5-fold (0.40 log units) above it, within the range that was stated.
By their numbers in this assay, from the lowest: compounds 1, 3 and 4 (each within the scatter of the next); then compound 2.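

In this assay, for the compounds shown here, the step of no change at the digits printed from compound 3 to compound 4 (within the scatter) shows that this position accepts the non-aromatic oxolan-3-yl ring as well as the aromatic furan-3-yl ring, an exchange that no earlier pair had tested. The step of a 1.3-fold higher number from compound 1 to compound 4 (0.12 log units; within the scatter) puts oxolan-3-yl level with cyclopropyl too, and the step of a 13-fold lower number from compound 2 to compound 4 (1.10 log units; beyond the scatter) matches what furan-3-yl recovered from cyclohexyl, so among these four compounds only cyclohexyl stands apart at this place. No measured evidence bears on why the aromatic and non-aromatic rings read alike.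

The compounds shown leave open whether the cost of cyclohexyl goes with a six-membered ring as such, which a phenyl or tetrahydropyran-4-yl ring here would test. Also open, going by these compounds, is how an open chain such as n-butyl would compare with these rings.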